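The compounds below may be only part of what the source reports. "The series", "measured", "known", "first", "only" and "open" are said of these compounds alone.

Measured so far: compound 1 `O=C(N/N=C/c1coc2ccc(O)cc2c1=O)c1cc2ccccc2[nH]1` and compound 2 `Cc1ccc2occ(/C=N/NC(=O)c3cc4ccccc4[nH]3)c(=O)c2c1`. In an assay for inhibition of Alpha amylase (Homo sapiens) (a higher number here means a weaker inhibitor, a lower number a stronger inhibitor), compound 1 gives 151000 nM. In this assay compound 2 gives only a limit, > 200000 nM, and so stands at the limit of > 200000 nM in this assay, at which 1 of the 2 values shown sits.

Compound 3 `O=C(N/N=C/c1coc2ccccc2c1=O)c1cc2ccccc2[nH]1` differs from compound 2 by hydrogen in place of methyl on an aromatic carbon. Going by the values given here, the only measured step, an at least 1.3-fold higher number from compound 1 to compound 2 (0.12 log units; that floor lies within the scatter), concerns another group and stays within the scatter, so it gives no direction for the present change. For compound 3 the step of a number no higher from compound 2 to compound 3 (the limit leaves the size open) is therefore expected to remain within the scatter. Compound 3 is estimated at 200000 nM, with a range from 100000 nM to 400000 nM, and may again be reported only as a limit.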

Compound 3, half-maximal inhibitory concentration: 128000 nM
Compound 3: middle estimate off by 1.6-fold (0.19 log units), on the high side, and the stated range covers the measured number.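

Going by these compounds alone, compound 3 gives the first comparison at this position with the aromatic carbon carrying only hydrogen: in this assay the change from hydroxy gives a 1.2-fold lower number from compound 1 to compound 3 (0.07 log units; within the scatter), so hydrogen and hydroxy are not told apart here. The change from methyl gives an at least 1.5-fold lower number from compound 2 to compound 3 (0.19 log units; that floor lies within the scatter), and no change at this position has yet been shown to go beyond the scatter. The true size of that step stays open because compound 2 gives only a limit: the limit of > 200000 nM in this assay, at which 1 of the 3 values shown sits.

The compounds shown leave open whether an amine, a carboxylic acid or a longer chain on this carbon would shift this assay beyond the scatter. All three values also remain weak, and how far this position can move them is unresolved.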